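A few compounds are considered here, and "the series" means these few. Any claim that something is new, unique, unknown or untested is made for them only; others in the source may bear on it.

The measured compounds:
compound 1 `CC(C)N1CCN(Cc2csc(N)c2C(=O)c2ccc(Cl)cc2)CC1`: 0%
compound 2 `Nc1scc(CN2CCN(c3ccc(Cl)c(C(F)(F)F)c3)CC2)c1C(=O)c1ccc(Cl)cc1`: 0%
compound 3 `Nc1scc(CN2CCN(c3cccnc3)CC2)c1C(=O)c1ccc(Cl)cc1`: 0%

In an assay on CHO cells for displacement of a labelled ligand from adenosine receptor A1 (Homo sapiens), read by scintillation counting, with a stated time of 120 min, tested at 10 uM (a higher number here means more inhibition at the concentration tested (going by the name of the read-out), a lower number less inhibition), compound 3 gives 0%, the same reading as compound 1, which gives 0%, and as compound 2, which gives 0%. None of the three shows any inhibition at the concentration tested. The step to compound 4 `Nc1scc(CN2CCN(c3ccc(F)c(F)c3)CC2)c1C(=O)c1ccc(Cl)cc1` again alters only the group on the amine nitrogen in the ring: 3,4-difluorophenyl in place of pyridin-3-yl on an amine nitrogen in a ring. Among the compounds with values here, three measured steps bear on it, each of them a swap of the group on that same ring nitrogen: no change at the digits printed from compound 1 to compound 2 (within the scatter), no change at the digits printed from compound 1 to compound 3 (within the scatter) and no change at the digits printed from compound 2 to compound 3 (within the scatter). Isopropyl, 4-chloro-3-(trifluoromethyl)phenyl and pyridin-3-yl all left the reading flat, so a fourth aromatic group at that position is expected to do the same, and no step beyond the scatter is expected: no change at the digits printed from compound 3 to compound 4 (within the scatter). Compound 4 is therefore estimated at 0% in this assay, with a range from 0% to 10%.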

Compound 4, a percentage reported as inhibition, at one concentration (the size of the read-out at that concentration, not a potency): 0%
Beside the measured number, compound 4's estimate shows no gap at the digits printed; low and high end bracket the measured number.
By their numbers in this assay, from the lowest: compounds 1, 2, 3 and 4 (each within the scatter of the next).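

Replacing the ring with a hetero atom by an aromatic ring of carbon only, now carrying fluorine, gives in this assay no change at the digits printed from compound 3 to compound 4 (within the scatter), so the reading at this amine nitrogen does not depend on that ring nitrogen being present. The fluorinated ring also reads the same as the chlorinated, trifluoromethyl-bearing ring, with no change at the digits printed from compound 2 to compound 4 (within the scatter), and the same as the open-chain isopropyl group, with no change at the digits printed from compound 1 to compound 4 (within the scatter). No measurement here offers an explanation for this flat result.

With all four compounds showing no inhibition, the series cannot rank these groups or show whether this position matters at all for this assay. On these data alone, whether a carboxylic acid, a benzyl group or a longer alkyl chain on that ring nitrogen would give any inhibition remains open.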